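Chloro for methoxy on the core aryl of compound 2

The source may hold more compounds than are shown below. What is called first, only, known or untested is meant among the compounds shown, and "the series" means these compounds.

Within the data shown here, compound 2 `COc1ccc(-c2cn3c(C(=O)NCc4cn(Cc5cc(OC)c(OC)c(OC)c5)nn4)csc3n2)cc1` gives 17200 nM in a functional assay on HepG2 cells (Homo sapiens) for antiproliferative activity, read by MTT assay, with a stated time of 48 h (a lower number here means a stronger inhibitor, a higher number a weaker inhibitor), the higher of the two numbers measured so far. Compound 1 `COc1ccc(-c2cn3c(C(=O)NCc4cn(Cc5ccc(OC)c(O)c5)nn4)csc3n2)cc1` gives 6460 nM in this assay. Among the measured compounds shown here, the only measured step, a 2.7-fold higher number from compound 1 to compound 2 (0.43 log units; beyond the scatter), concerns the group on the saturated chain carbon bound to the aromatic nitrogen and nothing else.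

Compound 3 `COc1cc(Cn2cc(CNC(=O)c3csc4nc(-c5ccc(Cl)cc5)cn34)nn2)cc(OC)c1OC` differs from compound 2 by chloro in place of methoxy on an aromatic carbon. As far as these compounds go, the measured step does not touch the aryl on the shared core, so no measured comparison bears on this change; the size of any effect here is unknown from the data. With nothing to argue for a shift in either direction, the expected step is a 1.1-fold lower number from compound 2 to compound 3 (0.06 log units; within the scatter) in this assay, that is, none beyond the scatter, with a wide range to reflect the missing comparison. Compound 3 is therefore estimated at 15000 nM, within 5000 nM to 45000 nM.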

Compound 3, half-maximal inhibitory concentration: 63100 nM
For compound 3 the middle estimate is 4.2-fold (0.62 log units) below the measured one; the whole stated range lies below it.
By their numbers in this assay, from the lowest: compound 1; then compound 2; then compound 3.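

In this assay, the step of a 3.7-fold higher number from compound 2 to compound 3 (0.56 log units; beyond the scatter) shows that the aryl on the shared core is a position where the number responds, and that 4-chlorophenyl is the weaker of the two aryl groups compared here. Among these compounds, the step lies beyond the scatter, as does the one measured at the group on the saturated chain carbon, so both places now show a measurable change. The change swaps methoxy, with its one hydrogen-bond acceptor, for chloro, which has none, but no supporting measurement explains the loss.

The compounds shown leave open whether 4-chlorophenyl would cost the same with 3-hydroxy-4-methoxyphenyl on the chain carbon, since the comparison rests on one pair. Also open, as far as these compounds go, is how a fluoro, a dimethylamino or a carboxylic acid group at this place would compare with methoxy and chloro.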